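A Halogen Swap Repeated on a Second Core

The source may hold more compounds than are shown below. What is called first, only, known or untested is meant among the compounds shown, and "the series" means these compounds.

Of the compounds shown here, three have been tested in a functional assay on MDA-MB-231 cells (Homo sapiens) for cytotoxicity, read by MTT assay, with a stated time of 24 h; on this read-out lower numbers stand for stronger inhibition and higher numbers for weaker inhibition. Compound 1 `COc1ccc(/C=C2\CN(Cc3cn(Cc4cccc(Cl)c4)nn3)C/C(=C\c3ccc(OC)cc3)C2=O)cc1` gives 98000 nM, the highest number of the three. Compound 3 `Cc1ccc(/C=C2\CN(C(=S)SCc3cn(Cc4cccc(Cl)c4)nn3)C/C(=C\c3ccc(C)cc3)C2=O)cc1` gives 83000 nM, and compound 2 `Cc1ccc(/C=C2\CN(C(=S)SCc3cn(Cc4ccc(F)cc4)nn3)C/C(=C\c3ccc(C)cc3)C2=O)cc1` gives 45600 nM. Compound 2 and compound 3 share one core, while compound 1 is built on another; the difference between the two cores is not broken down here. Compound 1 and compound 3 lie within the usual scatter of each other, so no order can be read between them, whereas the gap between compound 1 and compound 2 is beyond it.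

The change from compound 3 to compound 2 is 4-fluorophenyl in place of 3-chlorophenyl on a saturated chain carbon bound to an aromatic nitrogen and it made a 1.8-fold lower number from compound 3 to compound 2 (0.26 log units; within the scatter).

Compound 4 `COc1ccc(/C=C2\CN(Cc3cn(Cc4ccc(F)cc4)nn3)C/C(=C\c3ccc(OC)cc3)C2=O)cc1` has not yet been measured. It arises from compound 1 by 4-fluorophenyl in place of 3-chlorophenyl on a saturated chain carbon bound to an aromatic nitrogen. Both changes sit at the same place, worded the same way, so this is the same change carried over to the other core.

The step expected here is a 1.8-fold lower number from compound 1 to compound 4 (0.25 log units; within the scatter), which rests on a 1.8-fold lower number from compound 3 to compound 2 (0.26 log units; within the scatter) seen on the other core. Within the data shown here, only that one step is known, and it lies within the scatter, so the expectation is a loose one. For compound 4 the estimate in this assay is 55000 nM, with a likely range from 25000 nM to 120000 nM.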

Compound 4, half-maximal inhibitory concentration: 70700 nM
For compound 4 the middle estimate is 1.3-fold (0.11 log units) below the measured one, and the stated range covers the measured number.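

In this assay, replacing the 3-chlorobenzyl group of compound 1 with 4-fluorobenzyl gives a 1.4-fold lower number from compound 1 to compound 4 (0.14 log units; within the scatter). Set beside the earlier step, the swap shows no measurable difference between the two cores, so in these two pairs it carries over from one core to the other without any surprise: the same change on two cores in this assay, a 1.8-fold lower number (0.26 log units; within the scatter) from compound 3 to compound 2 and a 1.4-fold lower number (0.14 log units; within the scatter) from compound 1 to compound 4, 1.3-fold (0.12 log units) apart, within the scatter of two such steps. This does not show that the swap truly alters the number on either core, since each step on its own lies within the scatter, and agreement between two such small steps is weak evidence that says nothing about any further core.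

From the compounds shown here alone, the swap changes the halogen and its place on the ring together, so what a 4-chlorobenzyl or 3-fluorobenzyl group would give on either core remains open, and with it the question of whether the halogen or its place matters more. Also open, going by these compounds, is whether a group of a different kind at this position, such as an amine or a carboxylic acid on the phenyl ring, would produce a step large enough to stand clear of the scatter.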